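The compounds below may be only part of what the source reports. "The series", "measured", "known", "first", "only" and "open" are said of these compounds alone.

Measured compounds:
Compound 1 `CCn1c(C(=O)NCCN)ccc1C(CC)(CC)c1ccc(OCC(O)C(C)(C)C)c(C)c1` gives 10 nM in an assay on HL-60 cells for agonist activity at vitamin D3 receptor (Homo sapiens), read by microscopy, with a stated time of 96 h; a lower number here means that less compound is needed, a higher number that more compound is needed for the effect.
Compound 2 `CCOC(=O)c1ccc(OC(=O)c2ccc(C(CC)(CC)c3ccc(OCC(O)C(C)(C)C)c(C)c3)n2CC)cc1` gives only a limit of this assay, > 50000 nM.

Compound 2 therefore stands at the insensitive end of this assay, with no number of its own, only the limit (the limit of > 50000 nM in this assay, at which 1 of the 2 values shown sits). Among the compounds with values here, the one measured step, an at least 5000-fold higher number from compound 1 to compound 2 (3.69 log units; beyond the scatter), shows that exchanging the amide for an aryl ester costs almost all activity. Compound 3 `CCn1c(C(=O)OCc2ccc(F)cc2)ccc1C(CC)(CC)c1ccc(OCC(O)C(C)(C)C)c(C)c1` keeps the ester but changes its alcohol part: 4-fluorobenzyl in place of 4-(ethoxycarbonyl)phenyl on an oxygen next to a carbonyl group. Within the data shown here, no measured step covers an ester-to-ester exchange, and because compound 2 sits at the limit of > 50000 nM in this assay, at which 1 of the 2 values shown sits, no number of its own fixes the starting point. The step estimated for compound 3 is an at least 2.5-fold lower number from compound 2 to compound 3 (0.39 log units; beyond the scatter), an expectation only. Compound 3 is expected to remain weak, estimated at 20000 nM, within 2000 nM to 50000 nM, with a real chance that this assay again reports only a limit.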

Compound 3, half-maximal effective concentration: > 50000 nM
Compound 3: only a limit was reported; the forecaster's own chance of this, stated with the estimate: 50%; middle value at least 2.5-fold (0.39 log units) away from the limit.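

In this assay compound 3 gives > 50000 nM as its reading, and that is a limit of the assay, not a number. With a quite different alcohol part on the ester, the loss persists: (4-fluorobenzyl)oxy in place of (2-aminoethyl)amino on a carbonyl carbon gives an at least 5000-fold higher number from compound 1 to compound 3 (3.69 log units; beyond the scatter), so across these two esters the loss is not tied to the 4-(ethoxycarbonyl)phenyl group. The step between the two esters cannot be read, because both stop at the same limit: the limit of > 50000 nM in this assay, at which 2 of the 3 values shown sit.

As far as these compounds go, what stays open is whether the activity of compound 1 depends on the amide link itself or on the amine at the end of its chain. A plain ethyl amide or a carboxylic acid on the same carbonyl carbon would help separate these two possibilities.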